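Removing a Ring Fluorine from Two Nucleoside Cores

This account rests on a few compounds, and the source may have more. Where it says the series, first, only, none or still open, it means among the compounds named here.

compound 1 `Nc1ccn([C@H]2O[C@@H](CO)C=C2F)c(=O)n1`: > 100000 nM
compound 2 `Nc1nc(F)nc2c1ncn2[C@H]1O[C@@H](CO)C=C1F`: 173000 nM
compound 3 `Nc1nc(=O)n([C@H]2O[C@@H](CO)C=C2F)cc1F`: > 100000 nM

Three compounds were run in a functional assay on Vero cells (Chlorocebus sabaeus) for inhibition; a lower number here means a stronger inhibitor, a higher number a weaker inhibitor. Compound 2 gives 173000 nM. For compound 1 the result is a limit of the assay, > 100000 nM, not a number. For compound 3 the result is also a limit, > 100000 nM. Compound 3 and compound 1 differ by hydrogen in place of fluoro on an aromatic carbon; the step that the two limits leave unreadable from compound 3 to compound 1 cannot be sized because of the limit of > 100000 nM in this assay, at which 2 of the 3 values shown sit.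

Compound 4 `Nc1ncnc2c1ncn2[C@H]1O[C@@H](CO)C=C1F` is still unmeasured. It differs from compound 2 by hydrogen in place of fluoro on an aromatic carbon, the same kind of change as from compound 3 to compound 1, though the surroundings differ: in compound 4 the carbon sits between two ring nitrogen atoms of a fused system, in compound 1 ortho to an amino group. The difference between the core of compound 2 and the core of compound 3 is not broken down here. Within the data shown here, since the one measured step of this kind gives no size, the step expected here is a 1.0-fold lower number from compound 2 to compound 4 (0.01 log units; within the scatter), near no change. Compound 4 is estimated at 170000 nM, from 40000 nM to 700000 nM.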

Compound 4, half-maximal inhibitory concentration: > 100000 nM
Compound 4 ended at the assay's limit; the forecaster's own chance of this, stated with the estimate: 45%; the middle value is on the limit's open side.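

Compound 4's result is a limit of the assay, not a number, so the step from compound 2 to it cannot be read, because of this: the limit of > 100000 nM in this assay, at which 3 of the 4 values shown sit.

On these data alone, whether replacing fluoro with hydrogen changes inhibition at all stays open for both cores.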